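A few compounds are considered here, and "the series" means these few. Any claim that something is new, unique, unknown or untested is made for them only; others in the source may bear on it.

compound 1 (`CCn1cc(-c2nc3ccccc3o2)c(=O)c2cc(F)c(Cl)cc21`) gives 10200 nM 
compound 2 (`CCn1cc(-c2nc3ccccc3o2)c(=O)c2cc(F)c(N3CCNC(C)C3)c(F)c21`) gives 18900 nM 

Among the measured compounds shown here, in a functional assay on KB cells (Homo sapiens) for cytotoxicity, read by MTT assay, with a stated time of 48 h (on this read-out lower numbers stand for stronger inhibition and higher numbers for weaker inhibition), compound 1 at 10200 nM stands within the scatter of compound 2, the only other measured member of the series, so the two cannot be ranked.

Compound 3 (`CCn1cc(-c2nc3ccccc3o2)c(=O)c2cc(F)c(N3CCN(C)CC3)cc21`) has 4-methylpiperazin-1-yl in place of chloro on an aromatic carbon of the core of compound 1, ortho to a fluoro group (4-methylpiperazin-1-yl in place of chloro on an aromatic carbon).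

For the measured compounds named here, no measured pair differs in one place only, so this exchange has no direct precedent in the data. Going by the values given here, the sole guide is that compound 2 at 18900 nM lies within the scatter of compound 1. In this assay no step beyond the scatter is therefore expected, with a slight lean toward a higher number. The estimated step of a 1.4-fold higher number from compound 1 to compound 3 (0.14 log units; within the scatter) is expected to be small, and the uncertainty around it is wide. Compound 3 is expected at 14000 nM with an estimated range from 5000 nM to 40000 nM for now.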

Compound 3, half-maximal inhibitory concentration: 87400 nM
For compound 3 the middle estimate is 6.2-fold (0.80 log units) below the measured one; measured number above the stated range.
By their numbers in this assay, from the lowest: compounds 1 and 2 (each within the scatter of the next); then compound 3.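

In this assay, among the compounds shown here, chloro and 4-methylpiperazin-1-yl on the same aromatic carbon, ortho to a fluoro group, are separated by an 8.6-fold higher number from compound 1 to compound 3 (0.93 log units; beyond the scatter) and this is the first single-place change that can be read. The step shows that this position of the shared core is not indifferent to its substituent, since it lies beyond the scatter. Here the exchange of a single chlorine atom for a seven-heavy-atom ring substituent goes with weaker inhibition, a reading that rests on this one pair and no data at hand assign the step to any feature of the entering group.

Open, going by these compounds, is whether a small group on this carbon, such as methoxy or a free amino group, stands nearer to chloro or to 4-methylpiperazin-1-yl on this read-out. Also open, on these data alone, is whether morpholine or a piperazine without the methyl group would give a step of similar size, which would help separate the contribution of the ring from that of its methyl group.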